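A benzyl ester on the fluoro core

This account rests on a few compounds, and the source may have more. Where it says the series, first, only, none or still open, it means among the compounds named here.

In a functional assay on HepG2 cells (Homo sapiens) for cytotoxicity, read by MTT assay (on this read-out higher numbers stand for weaker inhibition and lower numbers for stronger inhibition), the measured compounds stand thus:
- compound 1 `C=C1C(=O)[C@]23C[C@@]1(O)CC[C@H]2[C@@]12C=CC(=O)[C@](C)(C(=O)O1)[C@H]2[C@@H]3C(=O)OCc1ccccc1` gives (20500 nM)
- compound 2 `C=C1C(=O)[C@]23C[C@@]1(F)CC[C@H]2[C@@]12C=CC(=O)[C@](C)(C(=O)O1)[C@H]2[C@@H]3C(=O)OC` gives (40600 nM)

Within the data shown here, the values of compound 1 and compound 2 lie within the usual scatter of each other, so compound 2 stands level with the only other number available. Compound 3 `C=C1C(=O)[C@]23C[C@@]1(F)CC[C@H]2[C@@]12C=CC(=O)[C@](C)(C(=O)O1)[C@H]2[C@@H]3C(=O)OCc1ccccc1` keeps the core of compound 2 and differs from it by one change (phenyl in place of hydrogen on a saturated chain carbon bound to an oxygen next to a carbonyl group): phenyl in place of hydrogen on a saturated chain carbon bound to an oxygen next to a carbonyl group, which turns methoxycarbonyl into benzyloxycarbonyl. Among the measured compounds shown here, that benzyloxycarbonyl group also stands in compound 1 (20500 nM), yet no measured pair isolates it. In this assay only a small step towards lower numbers is therefore expected, perhaps none beyond the scatter. The estimate means a 1.6-fold lower number from compound 2 to compound 3 (0.19 log units; within the scatter) and no clear separation. Compound 3 is expected at 26000 nM (estimated range 11000 nM to 60000 nM).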

Compound 3, half-maximal inhibitory concentration: 44100 nM
Beside the measured number, compound 3's estimate is 1.7-fold (0.23 log units) below it; the measured number falls inside the stated range.
By their numbers in this assay, from the lowest: compounds 1, 2 and 3 (each within the scatter of the next, the first and the last beyond it).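

In this assay, phenyl in place of hydrogen on a saturated chain carbon bound to an oxygen next to a carbonyl group gives a 1.1-fold higher number from compound 2 to compound 3 (0.04 log units; within the scatter), so methoxycarbonyl and benzyloxycarbonyl stand level on this core. With benzyloxycarbonyl held constant, fluoro in place of hydroxy on a saturated ring carbon gives a 2.2-fold higher number from compound 1 to compound 3 (0.33 log units; beyond the scatter), a modest step and the only one of these two single changes that lies beyond the scatter. No measurement shown here offers an explanation for either step.

As far as these compounds go, whether a carboxylic acid or an amide in place of methoxycarbonyl would stand apart from these numbers remains open. So does whether an amine on that saturated ring carbon would extend the step seen with fluoro and hydroxy.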